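The source may hold more compounds than are shown below. What is called first, only, known or untested is meant among the compounds shown, and "the series" means these compounds.

Measured so far:

Compound 1, `COc1ccccc1N1CCN(CCCNc2cncnc2C(=O)N(C)C)CC1`, gives 3.98 nM.
Compound 2, `CN(C)C(=O)c1cccnc1NCCCN1CCN(c2ccccc2OC(F)(F)F)CC1`, gives 3.16 nM.

Both numbers come from a functional assay for antagonist activity at Alpha-1A adrenergic receptor (Oryctolagus cuniculus); on this read-out higher numbers stand for weaker binding and lower numbers for tighter binding. Compound 2 stands at the lower of the two numbers, but its nearest neighbour, compound 1, is so close that the two values lie within the ordinary scatter of this assay, so the data do not separate them. Compound 1 carries a methoxy on the aryl piperazine, compound 2 a trifluoromethoxy at the same place, and the two read-outs are practically the same.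

The next compound, compound 3, `CN(C)C(=O)c1cccnc1NCCCN1CCN(c2ccccc2C2CC2)CC1`, has not been measured in this assay. It differs from compound 2 in one respect: cyclopropyl in place of trifluoromethoxy on an aromatic carbon. The group sits on an aromatic carbon of a six-membered aromatic ring of carbon only, ortho to a large group.

Among the measured compounds shown here, no measured step is available for this change. Given that compound 1 with 3.98 nM and compound 2 with 3.16 nM hardly differ, a step of about the same small size, or none beyond the scatter, is expected, with a slight lean toward a higher number. The expected step is a 1.6-fold higher number from compound 2 to compound 3 (0.20 log units; within the scatter). Compound 3 is therefore estimated at 5 nM, with a range from 1.5 nM to 16 nM.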

Compound 3, dissociation constant: 0.631 nM
Beside the measured number, compound 3's estimate is 7.9-fold (0.90 log units) above it; measured number outside the range, below it.
By their numbers in this assay, from the lowest: compound 3; then compounds 2 and 1 (each within the scatter of the next).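

In this assay this position, on an aromatic carbon ortho to a large group, proves sensitive to the group it carries: cyclopropyl in place of trifluoromethoxy gives a 5.0-fold lower number from compound 2 to compound 3 (0.70 log units; beyond the scatter) and so moves the read-out beyond the scatter. The earlier compounds shown here could not show this, as compound 1 and compound 2 differ in more than one place and their values lie within the scatter of each other. The change removes 5 heavy atoms with 1 hydrogen-bond acceptor and no ring, and brings in 3 heavy atoms with no hydrogen-bond acceptor and a three-membered ring, but no measurement shown here tells which of these differences accounts for the step.

The compounds shown leave open whether the ring itself matters, which an isopropyl or a cyclobutyl on the same carbon would help to settle. They also leave open whether cyclopropyl would give a similar step on the core of compound 1.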